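The source may report more compounds than this note shows. Statements on the series, on what has been measured and on what is new or still open speak of the compounds shown alone.

Series notes. For the measured compounds named here, compound 1 `Cn1c(Cc2nn(C)c(=O)c3ccccc23)nnc1SCCCCCC(=O)Nc1ccc(Cl)cc1Cl` gives 4100 nM in an assay on isolated protein (Mus musculus) for inhibition of IL15-IL15 receptor (Homo sapiens), read by resazurin assay, with stated times of 30 min and 2.5 days (a lower number here means a stronger inhibitor, a higher number a weaker inhibitor), the second highest of the three numbers so far. Compound 2 `Cn1c(Cc2nn(C)c(=O)c3ccccc23)nnc1SCCCCCCCCCC(=O)Nc1ccc(Cl)cc1Cl`, with the longest chain, gives 2300 nM; the two values lie within the scatter of each other. Compound 3 `Cn1c(Cc2nn(C)c(=O)c3ccccc23)nnc1SCC(=O)Nc1ccc(Cl)cc1Cl`, with the shortest chain, gives 17300 nM, a higher number beyond the scatter from compound 1. Compound 4 `Cn1c(Cc2nn(C)c(=O)c3ccccc23)nnc1SCCCCCCCC(=O)Nc1ccc(Cl)cc1` has not been measured. Against compound 1 the change is 2-((4-chlorophenyl)carbamoyl)ethyl in place of (2,4-dichlorophenyl)carbamoyl on a saturated chain carbon, five bonds along the chain from a sulfur. The chain grows by two saturated carbons while one chlorine is dropped; only the chain length has any precedent here, and that precedent points toward a lower number. The step from compound 1 to compound 4 is expected to be small, a 1.4-fold lower number from compound 1 to compound 4 (0.14 log units; within the scatter), not beyond the scatter. For compound 4 the estimate is 3000 nM, with a range from 1200 nM to 8000 nM.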

Compound 4, half-maximal inhibitory concentration: 800 nM
Compound 4: middle estimate off by 3.8-fold (0.57 log units), on the high side; the whole stated range lies above it.
By their numbers in this assay, from the lowest: compound 4; then compounds 2 and 1 (each within the scatter of the next); then compound 3.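

In this assay, 2-((4-chlorophenyl)carbamoyl)ethyl in place of (2,4-dichlorophenyl)carbamoyl on a saturated chain carbon gives a 5.1-fold lower number from compound 1 to compound 4 (0.71 log units; beyond the scatter) and shows that this position tolerates the change and can respond to it. The replacement adds two saturated carbons and removes one chlorine together, so this single step cannot divide its size between the two. No evidence at hand bears on the reason for the step.

Which of the two changes carries the step remains open. So does how a carboxylic acid or an amine at the chain end would read.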